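Nitro on the styryl phenyl: a single change from compound 1

This account rests on a few compounds, and the source may have more. Where it says the series, first, only, none or still open, it means among the compounds named here.

Measured compounds:
compound 1 `O[C@@H](c1ccccc1)[C@H]1CO[C@H](c2ccccc2)[C@@H](C/C=C/c2ccccc2)C1`, 6060 nM
compound 2 `COc1ccc([C@@H]2OC[C@H]([C@@H](O)c3ccc(OC)c(OC)c3)C[C@H]2C/C=C/c2ccc(OC)c(OC)c2)cc1`, 29200 nM

Compound 1 holds the lowest number of the two in a functional assay on HeLa cells (Homo sapiens) for cytotoxicity, read by WST assay, with a stated time of 48 h; a higher number here means a weaker inhibitor, a lower number a stronger inhibitor; compound 2 sits well above it, beyond the scatter. Compound 3 `O=[N+]([O-])c1ccc(/C=C/C[C@H]2C[C@@H]([C@@H](O)c3ccccc3)CO[C@@H]2c2ccccc2)cc1` is not yet measured. It differs from compound 1 in one place: nitro in place of hydrogen on an aromatic carbon, read one bond further out, phenyl to 4-nitrophenyl. Among the measured compounds shown here, no measured pair shows such a change, so the step of a 1.2-fold lower number from compound 1 to compound 3 (0.08 log units; within the scatter) is expected to be small, within or near the scatter, with no clear direction. Compound 3 is thus estimated at 5000 nM, in a range of 1500 nM to 16000 nM.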

Compound 3, half-maximal inhibitory concentration: 12400 nM
Beside the measured number, compound 3's estimate is 2.5-fold (0.39 log units) below it; measured number inside the range.
By their numbers in this assay, from the lowest: compound 1; then compound 3; then compound 2.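

In this assay, among the compounds shown here, going from phenyl to 4-nitrophenyl gives a 2.0-fold higher number from compound 1 to compound 3 (0.31 log units; beyond the scatter), the first single-place step in this set, as compound 1 and compound 2 offered none. It shows that this aromatic carbon is not silent: nitro in place of hydrogen here costs a modest amount of inhibition. Nothing measured here accounts for that step.

On these data alone, whether an amine, a carboxylic acid or a methoxy group on the same carbon would move the number in the same direction stays open. So does whether nitro would act alike on another carbon of this ring.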